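Adding a Methoxy Group to a Weak Calcium Channel Inhibitor

A few compounds are considered here, and "the series" means these few. Any claim that something is new, unique, unknown or untested is made for them only; others in the source may bear on it.

Three compounds have been measured in an assay on SH-SY5Y cells for inhibition of Voltage-dependent L-type calcium channel subunit alpha-1D (Homo sapiens), read by calcium flux, with a stated time of 15 min; a lower number here means a stronger inhibitor, a higher number a weaker inhibitor:

Compound 1 `CCOC(=O)C1=C(C)NC(c2ccccc2)=CC1c1ccccc1` gives 18700 nM
Compound 2 `CC1=C(C(=O)SC(C)(C)C)C(c2ccccc2)C=C(c2ccccc2)N1` gives 95800 nM
Compound 3 `CCOC(=O)C1=C(C)NC(c2ccc(Cl)cc2)=CC1c1ccccc1` gives 9300 nM

Among these, compound 1 stands second highest; the nearest step is a 2.0-fold lower number from compound 1 to compound 3 (0.30 log units; within the scatter), the furthest a 5.1-fold higher number from compound 1 to compound 2 (0.71 log units; beyond the scatter).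

Compound 4 `CCOC(=O)C1=C(C)NC(c2ccccc2)=CC1c1ccc(OC)cc1` has not yet been measured. It differs from compound 1 by methoxy in place of hydrogen on an aromatic carbon. For the measured compounds named here, no measured step touches this ring. The only aromatic substitution seen, a 2.0-fold lower number from compound 1 to compound 3 (0.30 log units; within the scatter), lies within the scatter, while the larger step concerns the ester, so no step beyond the scatter is expected here. Compound 4 is therefore estimated at 15000 nM, with a range from 5000 nM to 45000 nM, which means an expected 1.2-fold lower number from compound 1 to compound 4 (0.10 log units; within the scatter).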

Compound 4, half-maximal inhibitory concentration: 29800 nM
For compound 4 the middle estimate is 2.0-fold (0.30 log units) below the measured one; low and high end bracket the measured number.
By their numbers in this assay, from the lowest: compounds 3, 1 and 4 (each within the scatter of the next, the first and the last beyond it); then compound 2.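

In this assay, phenyl to 4-methoxyphenyl gives a 1.6-fold higher number from compound 1 to compound 4 (0.20 log units; within the scatter) and so stays within the scatter. For the compounds shown here, this is the first reading at this ring, and it shows that a methoxy, para to a large group, is accommodated here with no step beyond the scatter. Nothing shown offers a reason for this result.

On these data alone, whether an amine, a carboxylic acid or a longer chain such as butoxy at this place would give a step beyond the scatter remains open. So does the reading for methoxy on the other aromatic ring.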